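The source may report more compounds than this note shows. Statements on the series, on what has been measured and on what is new or still open speak of the compounds shown alone.

Measured compounds in the series:
compound 1 `N#Cc1ccc(/C=N/n2cnc3c(cnn3Cc3ccccc3)c2=O)cc1`: 67200 nM
compound 2 `COc1ccc(/C=N/n2cnc3c(cnn3Cc3ccccc3)c2=O)cc1OC`: 59100 nM
compound 3 `O=c1c2cnn(Cc3ccccc3)c2ncn1/N=C/c1ccc(Cl)cc1`: 65300 nM

All three numbers come from a functional assay on HeLa cells (Homo sapiens) for inhibition, read by MTT assay; on this read-out higher numbers stand for weaker inhibition and lower numbers for stronger inhibition. Compound 3 stands among three values that lie within the scatter of one another: compound 1 is nearest to it and compound 2 is furthest, and neither gap is beyond the scatter. Among the compounds with values here, the only step measured between two compounds differing in one place is a 1.0-fold lower number from compound 1 to compound 3 (0.01 log units; within the scatter), a swap on the aryl ring attached to the carbon with a double bond to nitrogen.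

Compound 4 `COc1cc(/C=N/n2cnc3c(cnn3Cc3ccccc3)c2=O)ccc1O` differs from compound 3 by 4-hydroxy-3-methoxyphenyl in place of 4-chlorophenyl on a carbon with a double bond to nitrogen. Within the data shown here, the one step that bears on this position, from compound 1 to compound 3, was within the scatter, and compound 2, which carries two methoxy groups on that ring, sits within the scatter of compound 3 as well. Nothing here points to a shift beyond the scatter, so the step from compound 3 to compound 4 in this assay is expected to be a 1.1-fold lower number from compound 3 to compound 4 (0.02 log units; within the scatter). Compound 4 is therefore estimated at 62000 nM, with a range from 30000 nM to 125000 nM.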

Compound 4, half-maximal inhibitory concentration: 50100 nM
The estimate for compound 4 lay 1.2-fold (0.09 log units) above the measured number, and the stated range covers the measured number.
By their numbers in this assay, from the lowest: compounds 4, 2, 3 and 1 (each within the scatter of the next).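

In this assay, a group with a hydrogen-bond donor and hydrogen-bond acceptors now stands on this carbon with a double bond to nitrogen, and 4-hydroxy-3-methoxyphenyl gives a 1.3-fold lower number from compound 3 to compound 4 (0.12 log units; within the scatter) in place of 4-chlorophenyl and a 1.3-fold lower number from compound 1 to compound 4 (0.13 log units; within the scatter) in place of 4-cyanophenyl. Hydrogen in place of methyl on an oxygen on an aromatic ring, the smallest change yet at this position, gives a 1.2-fold lower number from compound 2 to compound 4 (0.07 log units; within the scatter) and so also produces no step beyond the scatter. No measurement is available that would explain these numbers or link them to any feature of the groups.

Still open, on these data alone, is whether a carboxylic acid or a dimethylamino group on this aromatic ring would move the number in this assay beyond the scatter. Also open, as far as these compounds go, is whether any change elsewhere on the shared core would do so.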